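Aryl amide swap in a hydrazone cytotoxicity series

The source may hold more compounds than are shown below. What is called first, only, known or untested is meant among the compounds shown, and "the series" means these compounds.

The series shares one core, carried by compound 1 `C/C(=N\NC(=O)c1ccncc1)C(=O)Nc1ccc(F)cc1`, compound 2 `C/C(=N\NC(=O)c1ccncc1)C(=O)Nc1cccc(Cl)c1` and compound 3 `C/C(=N\NC(=O)c1ccncc1)C(=O)Nc1ccc(Cl)c(Cl)c1`, and differs only in the aryl group on the amide-type nitrogen. In a functional assay on HepG2 cells (Homo sapiens) for cytotoxicity, read by MTT assay, with a stated time of 72 h (a higher number here means a weaker inhibitor, a lower number a stronger inhibitor), compound 1 gives > 50000 nM, which is a limit of the assay and not a number. In this assay compound 2 gives > 50000 nM, again a limit. Compound 3 gives > 50000 nM in this assay, also a limit. Where compound 2 stands is thus only bounded, not located, since all three values sit at one limit (the limit of > 50000 nM in this assay, at which 3 of the 3 values shown sit). The step that the two limits leave unreadable from compound 1 to compound 2 and the step that the two limits leave unreadable from compound 2 to compound 3 cannot be read in size from two limits.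

The untested member is compound 4 `C/C(=N\NC(=O)c1ccncc1)C(=O)Nc1ccc(I)cc1`. Its change from compound 2 is 4-iodophenyl in place of 3-chlorophenyl on an amide-type nitrogen. Both measured steps alter the same aryl group on the same nitrogen, and neither gives a readable size, so no direction or size of step in this assay can be expected beyond the bare observation that every such change so far has left the value at the limit. Compound 4 is therefore estimated at 80000 nM, with an expected range from 20000 nM to 300000 nM. The step this estimate implies, a step that the limit leaves unreadable from compound 2 to compound 4, is expected to be unreadable, a further limit being the likeliest outcome.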

Compound 4, half-maximal inhibitory concentration: > 50000 nM
Compound 4 ended at the assay's limit; the forecaster's own chance of this, stated with the estimate: 85%; the middle value does not contradict the limit.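

In this assay compound 4 gives > 50000 nM, a limit and not a number. No step to compound 4 from compound 1 or compound 2 can be read in size: the limit of > 50000 nM in this assay, at which 4 of the 4 values shown sit.

The compounds shown leave open whether any aryl group on the amide-type nitrogen of the shared core gives a measurable value in this assay.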